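A few compounds are considered here, and "the series" means these few. Any claim that something is new, unique, unknown or untested is made for them only; others in the source may bear on it.

Measured in a functional assay on A-431 cells (Homo sapiens) for antiproliferative activity, read by MTT assay, with a stated time of 48 h; on this read-out higher numbers stand for weaker inhibition and lower numbers for stronger inhibition:
- compound 1 `O=C(CCCCCC(=O)Nc1ccc(O)c(C(=O)Nc2ccc(F)c(Cl)c2)c1)NO`: 3480 nM
- compound 2 `O=C(CCCCCC(=O)Nc1ccc(O)c(C(=O)Nc2ccc(Cl)c(Cl)c2)c1)NO`: 3800 nM

Compound 2 stands level with compound 1, their values lying within the scatter of each other. Compared with compound 2, compound 3 `O=C(CCCCCC(=O)Nc1ccc(O)c(C(=O)Nc2ccc(OCc3cccc(F)c3)c(Cl)c2)c1)NO` has (3-fluorobenzyl)oxy in place of chloro on an aromatic carbon. For the measured compounds named here, the only measured step, a 1.1-fold higher number from compound 1 to compound 2 (0.04 log units; within the scatter), merely exchanges one halogen for another and is a weak guide to so large a change. In this assay a modest move towards a lower number is expected, though the data do not settle the direction. The expected step is a 1.9-fold lower number from compound 2 to compound 3 (0.28 log units; within the scatter). For compound 3 the estimated value is 2000 nM, with an expected range of 600 nM to 7000 nM.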

Compound 3, half-maximal inhibitory concentration: 2600 nM
The estimate for compound 3 lay 1.3-fold (0.11 log units) below the measured number, and the stated range covers the measured number.
By their numbers in this assay, from the lowest: compounds 3, 1 and 2 (each within the scatter of the next).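

In this assay, the aromatic carbon ortho to a chloro group carries (3-fluorobenzyl)oxy, a far larger group than either halogen, which adds a six-membered aromatic ring of carbon only. The change gives a 1.5-fold lower number from compound 2 to compound 3 (0.16 log units; within the scatter) and a 1.3-fold lower number from compound 1 to compound 3 (0.13 log units; within the scatter), so in this assay the position takes more than a swap of one halogen for another without leaving the scatter. Nothing available explains this result. On these data alone, whether an amine or a carboxylic acid at this carbon would also leave the number level remains open, as does the effect of plain benzyloxy without the fluoro group.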